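Ethyl for hydrogen on the ring nitrogen of compound 1

The compounds below may be only part of what the source reports. "The series", "measured", "known", "first", "only" and "open" are said of these compounds alone.

Compound 1 `CCN(CC)CCCC(C)Nc1nc(NCc2ccc(Cl)cc2Cl)c2[nH]cnc2n1`: 4900 nM
Compound 2 `CCN(CC)CCCC(C)Nc1nc(NCc2ccc(Cl)cc2Cl)nc2nc[nH]c12`: 2100 nM

In an assay on HEK293 cells for displacement of a labelled ligand from C-C chemokine receptor type 4 (Homo sapiens) (a higher number here means a weaker inhibitor, a lower number a stronger inhibitor), compound 1 gives the higher of the two numbers; compound 2 gives 2100 nM, a gap beyond the scatter. Compound 3 `CCN(CC)CCCC(C)Nc1nc(NCc2ccc(Cl)cc2Cl)c2c(ncn2CC)n1` differs from compound 1 by ethyl in place of hydrogen on an aromatic nitrogen, the ethyl replacing a hydrogen on a ring nitrogen of the shared core. Among the compounds with values here, no measured pair shows such a change, so the step of a 2.0-fold lower number from compound 1 to compound 3 (0.29 log units; within the scatter) is an expectation only, guessed as a modest gain that may still fall within the scatter. Compound 3 is estimated at 2500 nM, within 900 nM to 7000 nM.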

Compound 3, half-maximal inhibitory concentration: 1100 nM
Beside the measured number, compound 3's estimate is 2.3-fold (0.36 log units) above it, and the stated range covers the measured number.
By their numbers in this assay, from the lowest: compounds 3 and 2 (each within the scatter of the next); then compound 1.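

In this assay ethyl in place of hydrogen on the aromatic nitrogen gives a 4.5-fold lower number from compound 1 to compound 3 (0.65 log units; beyond the scatter) and so supplies the first step read at this position. It shows that this ring nitrogen of the shared core can carry ethyl without loss, and that the hydrogen there is not needed for binding in this assay. Nothing shown explains the step. As far as these compounds go, whether methyl, a longer chain such as propyl or a benzyl group on the same nitrogen would go further remains open, and one step cannot show a trend.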